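Swapping chloro for nitro on a shared core

A few compounds are considered here, and "the series" means these few. Any claim that something is new, unique, unknown or untested is made for them only; others in the source may bear on it.

Measured so far in an assay on HEK293 cells for displacement of a labelled ligand from Neuronal acetylcholine receptor; alpha3/beta4 (Homo sapiens); on this read-out higher numbers stand for weaker inhibition and lower numbers for stronger inhibition:
compound 1 `Cc1ccc(Nc2cncc(N3CC4CC(C3)N4)c2)cc1`: 1.4 nM
compound 2 `Clc1ccc(Nc2cncc(N3CC4CC(C3)N4)c2)cc1`: 1.2 nM

Compound 2 gives 1.2 nM in this assay, the lowest of the two numbers. Compound 1 gives 1.4 nM, and the step of a 1.2-fold lower number from compound 1 to compound 2 (0.07 log units; within the scatter) lies within the scatter, so the two compounds cannot be told apart on this read-out.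

Compound 3 `O=[N+]([O-])c1ccc(Nc2cncc(N3CC4CC(C3)N4)c2)cc1` has not been measured. It differs from compound 2 by nitro in place of chloro on an aromatic carbon. Among the measured compounds shown here, the only measured step at this position, a 1.2-fold lower number from compound 1 to compound 2 (0.07 log units; within the scatter), is the one that bears on it: exchanging one small group for another there left the number essentially unchanged. Nitro was not among the groups tested, so that step is only a loose guide. On this basis a step of no more than modest size is expected for compound 3, a 1.7-fold higher number from compound 2 to compound 3 (0.22 log units; within the scatter), with a slight lean toward a higher number. Compound 3 is estimated at 2 nM in this assay, in a range from 0.7 nM to 6 nM.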

Compound 3, inhibition constant: 0.684 nM
Estimate against measurement, compound 3: 2.9-fold (0.47 log units) above; the measured number lies below the stated range.
By their numbers in this assay, from the lowest: compounds 3, 2 and 1 (each within the scatter of the next, the first and the last beyond it).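

In this assay the position accepts nitro, with its three heavy atoms and two hydrogen-bond acceptors, in place of chloro, with one heavy atom and none: the step is a 1.8-fold lower number from compound 2 to compound 3 (0.24 log units; within the scatter) and so compound 2 and compound 3 cannot be told apart. Set against methyl, the same group gives the first step at this position to clear the scatter, a 2.0-fold lower number from compound 1 to compound 3 (0.31 log units; beyond the scatter) and still only a modest one. Nothing available here gives a reason for the size of these steps.

On these data alone, all three compounds carry a single small group at this position, so it remains open whether an amine, a carboxylic acid or a longer chain there would keep the number this low. Also open, as far as these compounds go, is whether any of these groups would give similar numbers at another place on the same aromatic ring.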